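The source may report more compounds than this note shows. Statements on the series, on what has been measured and on what is new or still open speak of the compounds shown alone.

In a physicochemical assay for solubility, read by nephelometry, measured as kinetic solubility, at pH 2.0 (on this read-out higher numbers stand for higher solubility and lower numbers for lower solubility), compound 2 `CC(C)(C)c1cc(C(=O)Nc2cccnc2)n(Cc2ccccc2)n1` gives > 100 ug/mL, which is a limit of the assay and not a number. Compound 1 `CC(C)(C)c1cc(C(=O)Nc2ccccn2)n(Cc2ccccc2)n1` gives 25 ug/mL in this assay. For the measured compounds named here, the one measured step, an at least 4.0-fold higher number from compound 1 to compound 2 (0.60 log units; beyond the scatter), places pyridin-3-yl in place of pyridin-2-yl on an amide-type nitrogen and lies beyond the scatter. As far as these compounds go, its full size stays open because of the limit of > 100 ug/mL in this assay, at which 1 of the 2 values shown sits. Compound 3 `CNCc1csc(NC(=O)c2cc(C(C)(C)C)nn2Cc2ccccc2)n1` changes that same place again, with 4-((methylamino)methyl)-1,3-thiazol-2-yl in place of pyridin-3-yl (4-((methylamino)methyl)-1,3-thiazol-2-yl in place of pyridin-3-yl on an amide-type nitrogen). The step of an at least 4.0-fold higher number from compound 1 to compound 2 (0.60 log units; beyond the scatter) shows that a swap on this nitrogen can move the number visibly, but it involves a different group and gives no direction here. The expected result is no clear change, and the estimated step is a number no higher from compound 2 to compound 3 (the limit leaves the size open). Compound 3 is expected near 100 ug/mL, with an estimated range of 40 ug/mL to 200 ug/mL.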

Compound 3, solubility: 25 ug/mL
Compound 3: middle estimate off by 4.0-fold (0.60 log units), on the high side, and the stated range ends above it.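

In this assay the place on the amide-type nitrogen now shows a step down as well as a step up, with an at least 4.0-fold lower number from compound 2 to compound 3 (0.60 log units; beyond the scatter) when 4-((methylamino)methyl)-1,3-thiazol-2-yl replaces pyridin-3-yl. Set against pyridin-2-yl, the same group gives no change at the digits printed from compound 1 to compound 3 (within the scatter) here, so two quite different rings read alike and, among these three compounds, only pyridin-3-yl stands apart. As far as these compounds go, the full size of both steps that touch compound 2 stays open because its value is a limit and not a number: the limit of > 100 ug/mL in this assay, at which 1 of the 3 values shown sits.

The compounds shown do not separate the thiazole ring from its (methylamino)methyl side chain, so the reading for an unsubstituted 1,3-thiazol-2-yl remains open. Also open, from the compounds shown here alone, is how that ring would read with a carboxylic acid in place of the amine.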